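The source may hold more compounds than are shown below. What is called first, only, known or untested is meant among the compounds shown, and "the series" means these compounds.

Measured compounds:
compound 1, `COC(=O)Nc1cc(-c2ccc(OC[C@@](C)(N)CC(C)C)cn2)ccn1`, in an ADME assay on microsomes from liver (Rattus norvegicus) for metabolic stability, read by LC-MS, using NADPH, with a stated time of 10 min, tested at 0.5 uM (on this read-out higher numbers stand for a more stable compound and lower numbers for a less stable compound), gives 100%
compound 2, `COC(=O)Nc1cc(-c2cc(Cl)c(OC[C@@](C)(N)CC(C)C)cn2)ccn1`, gives 99%

Compound 2 sits at the same level as compound 1 on this read-out; the step of a number 1 percentage points lower from compound 1 to compound 2 (within the scatter) is within the scatter, so nothing separates the two. Compound 3, `COC(=O)Nc1cc(-c2cc(C)c(OC[C@@](C)(N)CC(C)C)cn2)ccn1`, is not yet measured. Its change from compound 2 is methyl in place of chloro on an aromatic carbon, on an aromatic carbon of a six-membered aromatic ring with 1 nitrogen, ortho to the (2-amino-2,4-dimethylpentyl)oxy group. Among the compounds with values here, the only step known, a number 1 percentage points lower from compound 1 to compound 2 (within the scatter), concerns chloro in place of hydrogen at this same carbon and left the number unchanged within the scatter; no step for methyl in place of chloro exists in the set. The step from compound 2 to compound 3 is therefore expected to be a number 3 percentage points lower from compound 2 to compound 3 (within the scatter), not beyond the scatter. For compound 3 the estimate is 96%, with a range from 85% to 100%.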

Compound 3, percent of the compound remaining: 100%
Estimate against measurement, compound 3: 4 percentage points below, and the stated range covers the measured number.
By their numbers in this assay, from the lowest: compounds 2, 1 and 3 (each within the scatter of the next).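

In this assay, methyl in place of chloro at the carbon opposite the ring nitrogen, ortho to the (2-amino-2,4-dimethylpentyl)oxy group, gives a number 1 percentage points higher from compound 2 to compound 3 (within the scatter) and methyl in place of hydrogen at that carbon gives no change at the digits printed from compound 1 to compound 3 (within the scatter) as well. Hydrogen, chloro and methyl are therefore not separated at this position on this read-out, so the flat result of the earlier pair is not peculiar to chloro. No supporting measurement is available to explain this flat result.

The compounds shown leave open whether methoxy, a nitrile or an amine at this carbon would move the number. All three values also lie together at the top of the read-out, so they do not show how this position behaves where the rest of the molecule gives a less stable compound.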